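What a bromo group may do to compound 1

This account rests on a few compounds, and the source may have more. Where it says the series, first, only, none or still open, it means among the compounds named here.

Compound 1 (`CCCCNc1cccn2c(-c3ccnc(NC4CCCC4)n3)c(-c3ccc(F)cc3)nc12`) gives 32000 nM.
Compound 2 (`COCCNc1cccn2c(-c3ccnc(NC4CCCC4)n3)c(-c3ccc(F)cc3)nc12`) gives > 40000 nM which is a limit.
Compound 3 (`Fc1ccc(-c2nc3ccccn3c2-c2ccnc(NC3CCCC3)n2)cc1`) gives > 40000 nM which is a limit.

Going by the values given here, in an ADME assay on Vero cells (Chlorocebus sabaeus) for cytotoxicity (on this read-out higher numbers stand for lower toxicity in this test and lower numbers for higher toxicity in this test), compound 1 gives 32000 nM as the only true number so far. The other two readings are limits (the limit of > 40000 nM in this assay, at which 2 of the 3 values shown sit). Compound 4 (`CCCCNc1cc(Br)cn2c(-c3ccnc(NC4CCCC4)n3)c(-c3ccc(F)cc3)nc12`) differs from compound 1 by one change (bromo in place of hydrogen on an aromatic carbon) with bromo in place of hydrogen on an aromatic carbon. Among the compounds with values here, no measured step adds a bromo group. Within the data shown here, the only guides are an at least 1.2-fold higher number from compound 1 to compound 2 (0.09 log units; that floor lies within the scatter) and an at least 1.2-fold higher number from compound 1 to compound 3 (0.09 log units; that floor lies within the scatter) and neither floor goes beyond the scatter. No step beyond the scatter is therefore expected in this assay in either direction. The expected change is a 1.3-fold lower number from compound 1 to compound 4 (0.11 log units; within the scatter). Compound 4 is estimated at 25000 nM with an expected range of 10000 nM to 40000 nM.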

Compound 4, half-maximal cytotoxic concentration: > 40000 nM
Compound 4 gave a limit, no number; the forecaster's own chance of this, stated with the estimate: 25%; middle value at least 1.6-fold (0.20 log units) away from the limit.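

In this assay, going by these compounds alone, putting a bromo group on this aromatic carbon, meta to the butylamino group, gives an at least 1.2-fold higher number from compound 1 to compound 4 (0.09 log units; that floor lies within the scatter) and so brings no sign of added toxicity at a position that the earlier compounds left unchanged. Compound 4 gives a limit, not a number, so the true size of the step stays hidden for this reason: the limit of > 40000 nM in this assay, at which 3 of the 4 values shown sit.

Going by these compounds, whether a larger group at this carbon, such as phenyl, or a carboxylic acid would bring a true number within the range of this test remains open.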